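Replacing the (Benzyloxy)amino Group with Methoxy

The compounds below may be only part of what the source reports. "The series", "measured", "known", "first", "only" and "open" are said of these compounds alone.

In a functional assay on HCT-116 cells (Homo sapiens) (on this read-out higher numbers stand for weaker inhibition and lower numbers for stronger inhibition), compound 1 `COc1cc(NC(C)CCCNC(=O)NOCc2ccccc2)c2ncccc2c1` gives 14000 nM. Compound 2 `COc1cc(NC(C)CCCNC(=O)NCCNC(=O)NCCCC(C)Nc2cc(OC)cc3cccnc23)c2ncccc2c1`, which carries the shared core twice, gives 15000 nM, so compound 1 stands level with it, within the scatter. Within the data shown here, these are the only two true numbers so far.

Compound 4 `COC(=O)NCCCC(C)Nc1cc(OC)cc2cccnc12` has not yet been measured. It has methoxy in place of (benzyloxy)amino on a carbonyl carbon.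

Among the measured compounds shown here, no measured pair isolates this change, so any expectation is rough. Compound 3 `COc1cc(N2C(=O)NCCCC2C)c2ncccc2c1`, which also lacks the (benzyloxy)amino group, gives > 100000 nM, and this is a limit of the assay rather than a number. Compound 2 goes against reading much into that, since it lacks the group too and still gives 15000 nM.

A moderate move towards weaker inhibition therefore seems likely, and the estimated step is a 2.9-fold higher number from compound 1 to compound 4 (0.46 log units; beyond the scatter). For compound 4 the expected value is 40000 nM, with an estimated range from 12000 nM to 100000 nM.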

Compound 4, half-maximal inhibitory concentration: > 100000 nM
Compound 4: only a limit was reported (the forecaster's own chance of this, stated with the estimate: 30%); middle value at least 2.5-fold (0.39 log units) from the limit.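

Among these compounds, putting methoxy in place of (benzyloxy)amino on a carbonyl carbon gives an at least 7.1-fold higher number from compound 1 to compound 4 (0.85 log units; beyond the scatter), and this is the first pair in which only this one place differs. In this pair, the measurable inhibition of compound 1 does not survive cutting the group back to methoxy, although this holds for this pair alone: compound 2, which also lacks (benzyloxy)amino, gives 15000 nM in this assay. Compound 4 gives > 100000 nM, which is a limit of the assay and not a number, so the true size of the step stays open: the limit of > 100000 nM in this assay, at which 2 of the 4 values shown sit.

As far as these compounds go, it remains open which part of the (benzyloxy)amino group counts, the six-membered aromatic ring or the link of nitrogen and oxygen. A benzylamino group, which keeps the ring without that oxygen, or an unbranched butoxy chain, which has no ring, on the same carbonyl carbon could separate the two.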